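This account rests on a few compounds, and the source may have more. Where it says the series, first, only, none or still open, it means among the compounds named here.

Compound 1 `COc1cc(Cl)cc(-c2nn(-c3cccc(NC(=O)Nc4ccc(Cl)c(C(F)(F)F)c4)c3)cc2-c2ccncc2)c1` and compound 2 `COc1cc(Cl)cc(-c2nn(-c3cccc(NC(=O)Nc4ccc(Cl)c(Cl)c4)c3)cc2-c2ccncc2)c1` share one core and differ only in the group on the outer ring of the urea. In a functional assay on OVCAR-3 cells (Homo sapiens) for inhibition, read by sulforhodamine B assay, with a stated time of 48 h, tested at 1 uM (on this read-out higher numbers stand for a weaker effect at the one concentration tested and lower numbers for a stronger effect), compound 1 gives 24%, while compound 2 gives 61%, the highest of the two numbers seen so far. Among the compounds with values here, the single measured step, a number 37 percentage points higher from compound 1 to compound 2 (beyond the scatter), shows that exchanging the trifluoromethyl for a chloro moved the read-out well beyond the scatter toward a weaker effect.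

Compound 3 `COc1cc(Cl)cc(-c2nn(-c3cccc(NC(=O)Nc4cccc(C(F)(F)F)c4)c3)cc2-c2ccncc2)c1` is not yet measured. Relative to compound 2 it carries 3-(trifluoromethyl)phenyl in place of 3,4-dichlorophenyl on an amide-type nitrogen. Within the data shown here, this partly reverses the earlier change, because a number 37 percentage points higher from compound 1 to compound 2 (beyond the scatter) was large the return of a trifluoromethyl may pull the number back down, yet compound 3 also loses the remaining chloro, for which no step exists. Compound 3 is therefore expected to show a number 21 percentage points lower from compound 2 to compound 3 (beyond the scatter). Compound 3 is estimated at 40%, within 15% to 70%.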

Compound 3, a percentage reported as activity, at one concentration (the size of the read-out at that concentration, not a potency): 38%
For compound 3 the middle estimate is 2 percentage points above the measured one; low and high end bracket the measured number.
By their numbers in this assay, from the lowest: compound 1; then compound 3; then compound 2.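

Compound 3 lets the two groups of compound 1 be read apart: with the trifluoromethyl kept, hydrogen in place of the chloro gives a number 14 percentage points higher from compound 1 to compound 3 (beyond the scatter) in this assay and so shows that the chloro goes with a stronger effect even when the trifluoromethyl is present. The change of 3,4-dichlorophenyl to 3-(trifluoromethyl)phenyl on the amide-type nitrogen gives a number 23 percentage points lower from compound 2 to compound 3 (beyond the scatter) and thus shows that a lone trifluoromethyl, without any chloro, still gives a stronger effect here than the two chloro groups of compound 2. No measurement at hand explains either step.

Still open, as far as these compounds go, is how a methoxy, a nitrile or an amine would compare with the trifluoromethyl in this place, and what a bare phenyl would give. These numbers also come from one concentration, so they describe the size of the effect there and not potency.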